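The source may report more compounds than this note shows. Statements on the series, on what has been measured and on what is new or still open speak of the compounds shown alone.

Measured compounds:
- compound 1 `COc1cccc(C(=O)NCc2ccc(CNS(=O)(=O)c3ccc(C)cc3)cc2)c1`: 10 nM
- compound 2 `O=C(NCc1ccc(CNS(=O)(=O)c2ccccc2)cc1)c1cccnc1`: 10 nM
- compound 3 `O=C(NCc1ccc(CNS(=O)(=O)c2ccccc2)cc1)c1ccccc1F`: 1000 nM

In an assay on MDA-MB-231 cells for binding affinity to C-X-C chemokine receptor type 4 (Homo sapiens), read by immunofluorescence and microscopy, with stated times of 10 min and 30 min (on this read-out lower numbers stand for an effect already at smaller amounts and higher numbers for an effect only at larger amounts of compound), compound 1 gives 10 nM, level at the digits shown with compound 2, so that together they give the lowest numbers of the three. Within the data shown here, compound 3 sits far from them: there is a 100-fold higher number from compound 2 to compound 3 (2.00 log units; beyond the scatter) for the single change from pyridin-3-yl to 2-fluorophenyl on the carbonyl carbon.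

Compound 4 `COc1ccccc1C(=O)NCc1ccc(CNS(=O)(=O)c2ccc(C)cc2)cc1` is the next step from compound 1, with the change (2-methoxyphenyl in place of 3-methoxyphenyl on a carbonyl carbon). Among the measured compounds shown here, no measured step moves a methoxy group around a ring, so the only guidance is indirect: the one change made on the same carbonyl carbon, from compound 2 to compound 3, cost a large amount, and it too brought in a 2-substituted phenyl. A higher number is therefore expected for compound 4 in this assay, a step of a 10-fold higher number from compound 1 to compound 4 (1.00 log units; beyond the scatter), with wide uncertainty. Compound 4 is estimated at 100 nM, in the range 15 nM to 1000 nM.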

Compound 4, effective concentration (reported as EC, without a stated level of effect): 100 nM
For compound 4 middle estimate and measured number coincide at the digits printed; the range from low to high includes it.
By their numbers in this assay, from the lowest: compounds 1 and 2 (each within the scatter of the next); then compound 4; then compound 3.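

Swapping 3-methoxyphenyl for 2-methoxyphenyl on the carbonyl carbon gives a 10-fold higher number from compound 1 to compound 4 (1.00 log units; beyond the scatter) in this assay, even though the two groups contain the same atoms. Compounds 2 and 3 showed that exchanging one ring for another at this place can matter; this step shows that moving a single methoxy group on the same ring also matters. Nothing available explains the shift. From the compounds shown here alone, whether a hydroxyl group or an amine in place of the methoxy group would give a lower or higher number remains open.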